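The source may hold more compounds than are shown below. What is called first, only, known or untested is meant among the compounds shown, and "the series" means these compounds.

Of the compounds shown here, two have been measured in an assay on a protein complex for inhibition of CDK8/Cyclin C (Homo sapiens), with a stated time of 1 h; on this read-out higher numbers stand for weaker inhibition and lower numbers for stronger inhibition. Compound 1, `COC1CN(C(=O)/C=C/c2ccncc2-c2ccc3ccccc3c2)C1`, gives 42.8 nM in this assay, the lower of the two numbers obtained so far. Compound 2, `O=C(/C=C/c1ccncc1-c1ccc2[nH]ccc2c1)N1CCOCC1`, gives 190 nM in this assay, a higher number that lies well beyond the usual scatter of the measurement, so compound 1 stands as the stronger inhibitor of the pair.

Compound 3, `O=C(/C=C/c1ccncc1-c1ccc2ccccc2c1)N1CCOCC1`, has not yet been measured. It keeps the whole core of compound 1 and differs only at the amide end: morpholin-4-yl in place of 3-methoxyazetidin-1-yl on a carbonyl carbon. Both groups that change places are counted with the same atoms, joined into rings of different size. Among the compounds with values here, no measured pair in the set isolates this change, so its effect in this assay can only be guessed from the shared core of compound 1. Since the rest of the molecule is unchanged, the step from compound 1 to compound 3 is expected to be small in this assay, a 1.3-fold higher number from compound 1 to compound 3 (0.11 log units; within the scatter), likely within the scatter or at most a modest weakening. Compound 3 is therefore estimated to give 55 nM in this assay, with a range from 20 nM to 150 nM.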

Compound 3, half-maximal inhibitory concentration: 60.3 nM
Beside the measured number, compound 3's estimate is 1.1-fold (0.04 log units) below it; low and high end bracket the measured number.
By their numbers in this assay, from the lowest: compounds 1 and 3 (each within the scatter of the next); then compound 2.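

In this assay this carbonyl position now has its first direct reading, which is a 1.4-fold higher number from compound 1 to compound 3 (0.15 log units; within the scatter) when morpholin-4-yl stands in place of 3-methoxyazetidin-1-yl. The two amide ends have the same count of heavy atoms and hydrogen-bond acceptors, yet one is a four-membered ring with one hetero atom and the other a six-membered ring with two, and on this single pair that exchange does not separate the two compounds beyond the usual scatter. No independent measurement accompanies this pair, so the result stands without an explanation.

This reading rests on one pair with one shared core, so it cannot be said whether the same holds when the core of compound 2 is carried or when other rings stand on the carbonyl carbon. On these data alone, it also stays open how the read-out responds to a piperazin-1-yl ring with a free ring nitrogen, to an open-chain dimethylamino group or to a carboxylic acid on a longer chain at this place.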